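The source may report more compounds than this note shows. Statements on the series, on what has been measured and on what is new or still open speak of the compounds shown alone.

Working notes on the series: compound 1 `CC(C)(C)C(=O)N1N=CCC1c1ccc(S(C)(=O)=O)cc1` and compound 2 `CC(C)(C)C(=O)N1N=CCC1c1ccc(C(C)(C)C)cc1` share one core. In a physicochemical assay for lipophilicity, read by HPLC, measured as chromatographic lipophilicity, at pH 7.4 (on this read-out higher numbers stand for higher lipophilicity and lower numbers for lower lipophilicity), compound 1 gives 4.1 and compound 2 gives 8 as the higher of the two numbers. Next comes compound 3 `CC(C)(C)C(=O)N1N=CCC1c1ccc(Cl)cc1` with the change chloro in place of tert-butyl on an aromatic carbon in the same place: chloro in place of tert-butyl on an aromatic carbon. Among the compounds with values here, one measured step bears on it, tert-butyl in place of methylsulfonyl on an aromatic carbon, which gave a number 3.90 log units higher from compound 1 to compound 2 (beyond the scatter) in this assay as the only size reference. Within the data shown here, no chloro compound has been measured yet, so a fall is expected, smaller than that step, leaving compound 3 between the two measured compounds. The expected change a number 1.40 log units lower from compound 2 to compound 3 (beyond the scatter) is an estimate only. For compound 3 an expected 6.6 within an estimated range from 6 to 7.2 closes these notes.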

Compound 3, distribution coefficient: 6.6
Compound 3: middle estimate and measured number agree at the digits printed; the range from low to high includes it.
By their numbers in this assay, from the lowest: compound 1; then compound 3; then compound 2.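

In this assay, chloro in place of tert-butyl gives a number 1.40 log units lower from compound 2 to compound 3 (beyond the scatter), and chloro in place of methylsulfonyl gives a number 2.50 log units higher from compound 1 to compound 3 (beyond the scatter). This position, on an aromatic carbon para to a large group, therefore shows an order of three separated values rather than only two end points: compound 1, then compound 3, then compound 2. Tert-butyl and chloro both count no hydrogen-bond donors or acceptors, yet the step between them is large, so those counts do not separate compound 2 from compound 3.

No supporting data bear on why the three groups fall in this order. Going by these compounds, it remains open whether an amine, a carboxylic acid or a longer chain at this place would fall inside this span, and whether the order holds on another core.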